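Aryl swap on the shared core: pyridin-3-yl for 4-cyanophenyl

A few compounds are considered here, and "the series" means these few. Any claim that something is new, unique, unknown or untested is made for them only; others in the source may bear on it.

Working notes on a small set built around one shared core carrying a piperazine-linked pyrrolidine amide. Compound 1 `Cc1cc(N2CCN([C@@H]3CN[C@H](C(=O)N4CCSC4)C3)CC2)n(-c2ccc(F)cc2)n1` carries a 4-fluorophenyl on the aromatic nitrogen; in a functional assay on the whole organism (plasma, strain Wistar) for inhibition, with Rattus norvegicus as the target, read by fluorescence, with a stated time of 0.5 h, at a dose of 3 umol/kg by the oral route (a higher number here means more inhibition at the dose given (going by the name of the read-out), a lower number less inhibition), compound 1 gives "not determined" (no result reported). Among the compounds with values here, compound 2 `Cc1cc(N2CCN([C@@H]3CN[C@H](C(=O)N4CCSC4)C3)CC2)n(-c2cccc(F)c2)n1` carries a 3-fluorophenyl in the same place, and in this assay compound 2 gives 96.1%, the only number the set holds so far. Compound 3 `Cc1cc(N2CCN([C@@H]3CN[C@H](C(=O)N4CCSC4)C3)CC2)n(-c2ccc(C#N)cc2)n1` carries a 4-cyanophenyl; in this assay compound 3 gives "not determined" (no result reported), so compound 3 stands without a number, and a second compound in the set is in the same state. Within the data shown here, no step between two measured compounds can be drawn from these entries.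

Compound 4 `Cc1cc(N2CCN([C@@H]3CN[C@H](C(=O)N4CCSC4)C3)CC2)n(-c2cccnc2)n1` differs from compound 3 in one place: pyridin-3-yl in place of 4-cyanophenyl on an aromatic nitrogen. Among the measured compounds shown here, with no measured step from compound 3, the size and direction of this change cannot be read from the data; the only anchor is compound 2 at 96.1%, which points to a high read-out for this core, so no step beyond the scatter is expected from the aryl swap alone, with wide uncertainty. On that basis compound 4 is estimated at 85% in this assay, within a range from 50% to 100%.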

Compound 4, a percentage reported as inhibition, in the whole organism at one dose (the size of the read-out at that dose, not a potency): 66.9%
Estimate against measurement, compound 4: 18.1 percentage points above, and the stated range covers the measured number.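

In this assay, pyridin-3-yl in place of 3-fluorophenyl on the aromatic nitrogen gives a number 29.2 percentage points lower from compound 2 to compound 4 (beyond the scatter), the first measured size for a change at this position. The read-out at this dose therefore depends on the aryl group here, and the high value of compound 2 does not carry over to every aryl group on the shared core; the steps to compound 4 from compound 1 and compound 3 cannot be read, as neither has a number. The data at hand hold nothing that accounts for the size or direction of this step.

Pyridin-3-yl and 3-fluorophenyl differ both in the ring nitrogen and in the fluorine, so this single step cannot separate the two, and an unsubstituted phenyl on the same aromatic nitrogen would show how much of it goes with each. Also open, going by these compounds, is whether a methoxy group or a chlorine on the phenyl ring would hold the read-out near that of compound 2, and how far a read-out at one dose and one time reflects potency rather than the size of the effect at that dose.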